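Amino substitution on two related cores, A549 growth inhibition

This account rests on a few compounds, and the source may have more. Where it says the series, first, only, none or still open, it means among the compounds named here.

Measured so far in a functional assay on A549 cells (Homo sapiens) for antiproliferative activity, read by MTT assay, with a stated time of 48 h; a higher number here means a weaker inhibitor of growth, a lower number a stronger inhibitor of growth:
compound 1 `COc1ccc(/C=C2\Cc3c(cc(OC)c(OC)c3OC)C2=O)cc1` gives 273 nM
compound 2 `COc1ccc(/C=C2\Cc3c(cc(OC)c(OC)c3OC)C2=O)cc1N` gives 212 nM
compound 3 `COc1ccc(/C=C2\Cc3cc(OC)c(OC)c(OC)c3C2=O)cc1` gives > 10000 nM

The value of compound 3 is a limit of the assay, not a number, at the limit of > 10000 nM in this assay, at which 1 of the 3 values shown sits. Compound 1 and compound 3 have the same atoms joined differently; the difference between the two cores is not broken down here.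

From compound 1 to compound 2 the change is amino in place of hydrogen on an aromatic carbon. It made a 1.3-fold lower number from compound 1 to compound 2 (0.11 log units; within the scatter).

Compound 4 `COc1ccc(/C=C2\Cc3cc(OC)c(OC)c(OC)c3C2=O)cc1N` is not yet measured. It differs from compound 3 by amino in place of hydrogen on an aromatic carbon, the same change at the same kind of place as between compound 1 and compound 2.

Going by the values given here, since the one measured instance of this change, a 1.3-fold lower number from compound 1 to compound 2 (0.11 log units; within the scatter), stayed within the scatter, compound 4 is expected to remain close to compound 3, most likely again at the limit. Compound 4 is estimated at 12000 nM, with a range of 4000 nM to 40000 nM. For compound 4 this means an expected step that the limit leaves unreadable from compound 3 to compound 4.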

Compound 4, concentration for 50% growth inhibition: > 10000 nM
Compound 4: a limit, no number (the forecaster's own chance of this, stated with the estimate: 80%); the middle value lies beyond the limit too.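

In this assay compound 4 gives > 10000 nM, a limit and not a number, and compound 3 stands at the same limit, so no step can be read between compound 3 and compound 4. Still open, on these data alone, is whether amino in place of hydrogen on an aromatic carbon alters growth inhibition at all on the core of compound 3.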